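Fluoro in place of chloro on compound 3

The compounds below may be only part of what the source reports. "The series", "measured", "known", "first", "only" and "open" are said of these compounds alone.

In a functional assay on GBM1 cells (Homo sapiens) for antiproliferative activity, read by WST assay, with a stated time of 72 h (on this read-out lower numbers stand for stronger inhibition and higher numbers for weaker inhibition), compound 3 `O=C(Nc1ccccc1F)Nc1cc2ncncc2cc1OCc1cccc(Cl)c1` gives 4200 nM. This lies within the scatter of compound 2 `O=C(Nc1ccccc1F)Nc1cc2ncncc2cc1OCc1ccccc1F` at 4200 nM and of compound 1 `O=C(Nc1ccc(C(F)(F)F)cc1)Nc1cc2ncncc2cc1OCc1cccc(F)c1` at 3800 nM. Compound 4 `O=C(Nc1ccccc1F)Nc1cc2ncncc2cc1OCc1cccc(F)c1` differs from compound 3 in one place, with fluoro in place of chloro on an aromatic carbon. Going by the values given here, the only measured step that bears directly on this change alters the same aromatic ring, and its size lies within the scatter: no change at the digits printed from compound 2 to compound 3 (within the scatter). Compound 1 also carries the 3-fluorobenzyl group, though it differs elsewhere. No step beyond the scatter is expected in this assay, and the estimated step is a 1.1-fold lower number from compound 3 to compound 4 (0.02 log units; within the scatter). The expected value for compound 4 is 4000 nM, within an estimated range of 2000 nM to 8000 nM.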

Compound 4, half-maximal inhibitory concentration: 8000 nM
Estimate against measurement, compound 4: 2.0-fold (0.30 log units) below; the range from low to high includes it.
By their numbers in this assay, from the lowest: compounds 1, 2, 3 and 4 (each within the scatter of the next, the first and the last beyond it).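

Fluoro in place of chloro on this aromatic carbon stays small, a 1.9-fold higher number from compound 3 to compound 4 (0.28 log units; within the scatter), and moving the fluoro to give the 3-fluorophenyl group stays small as well, a 1.9-fold higher number from compound 2 to compound 4 (0.28 log units; within the scatter). Going by these compounds alone, the first step beyond the scatter comes from the other end of the molecule, where 2-fluorophenyl replaces 4-(trifluoromethyl)phenyl on the amide-type nitrogen, a 2.1-fold higher number from compound 1 to compound 4 (0.32 log units; beyond the scatter), though it is modest. Nothing measured here accounts for these steps.

The compounds shown leave open whether a methoxy group or an amine on this carbon would give a step beyond the scatter.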